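Shortening a butyl chain on a quinoline-triazole cytotoxicity series

This account rests on a few compounds, and the source may have more. Where it says the series, first, only, none or still open, it means among the compounds named here.

Measured compounds:
compound 1, `CCCCCCCCCCn1cc(-c2nc3ccccc3cc2CCCC)nn1`, > 100 ug/mL
compound 2, `Cc1cc2ccccc2nc1-c1cn(CCC(F)(F)C(F)(F)C(F)(F)C(F)(F)C(F)(F)C(F)(F)C(F)(F)C(F)(F)F)nn1`, > 100 ug/mL
compound 3, `Cc1cc2ccccc2nc1-c1cn(-c2ccc(F)cc2)nn1`, > 100 ug/mL

The three compounds were examined in a functional assay on HeLa cells (Homo sapiens) for cytotoxicity, read by MTT assay, with a stated time of 24 h; on this read-out higher numbers stand for weaker inhibition and lower numbers for stronger inhibition. Compound 1 gives > 100 ug/mL, which is a limit of the assay and not a number. Compound 2 likewise gives > 100 ug/mL, again a limit. Compound 3 gives > 100 ug/mL, also a limit. All three values therefore sit at the limit of > 100 ug/mL in this assay, at which 3 of the 3 values shown sit, so no ordering among them can be drawn, and compound 1 stands at the same limit as the other two.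

The next compound, compound 4, `CCCCCCCCCCn1cc(-c2nc3ccccc3cc2CCC)nn1`, has not yet been measured. It differs from compound 1 by hydrogen in place of methyl on a saturated chain carbon, three bonds along the chain from an aromatic carbon. Within the data shown here, no measured pair with this difference exists in the set. Since every value seen so far is a limit, a small change of this kind is expected to leave the read-out essentially unchanged, and the estimated step from compound 1 to compound 4 is a step that the limit leaves unreadable from compound 1 to compound 4, none beyond the scatter. Compound 4 is estimated at 150 ug/mL, with a range from 80 ug/mL to 400 ug/mL, and most likely the assay will again report only a limit.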

Compound 4, half-maximal inhibitory concentration: > 100 ug/mL
Compound 4 ended at the assay's limit (the forecaster's own chance of this, stated with the estimate: 85%); the middle value is on the limit's open side.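

No step can be read from compound 1 to compound 4, because both values are limits of the assay: the limit of > 100 ug/mL in this assay, at which 4 of the 4 values shown sit. The compounds shown leave open how strong any of them truly is, and whether going from butyl to propyl changes the read-out at all.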